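The source may report more compounds than this note shows. Statements on the series, on what has been measured and on what is new or still open speak of the compounds shown alone.

Measured compounds:
Compound 1, `O=C(CN(c1ncnc2c1ncn2C1CCCCO1)C1CC1)N[C@@H](CO)C(=O)OCc1ccccc1`: in a functional assay on the whole organism (Tail, strain ICR) with Mus musculus as the target, in the tail flick test, with a stated time of 30 min, at a dose of 25 umol/kg by the oral route (a higher number here means a stronger effect of the compound at the dose given, a lower number a weaker effect), compound 1 gives 27.8%.
Compound 2, `C[C@@H](O)[C@H](NC(=O)CN(c1nc(Cl)nc2[nH]cnc12)C1CC1)C(=O)O`: in this assay compound 2 gives 18.6%.

Compound 2 gives the lower of these two numbers, yet its gap to compound 1 lies within the scatter, so the two cannot be told apart. Compound 3, `N=C(N)NCCC[C@H](NC(=O)CN(c1nc(Cl)nc2[nH]cnc12)C1CC1)C(=O)O`, differs from compound 2 by a group of 7 heavy atoms (4 carbon, 3 nitrogen; no ring) in place of a group of 3 heavy atoms (2 carbon, 1 oxygen; no ring), on a saturated chain carbon bound to an amide-type nitrogen and a carbonyl carbon. For the measured compounds named here, no step between measured compounds is available to gauge such a change, so no direction can be read from the data; a step no larger than the scatter is expected in this assay, namely a number 1.4 percentage points higher from compound 2 to compound 3 (within the scatter). Compound 3 is therefore estimated at 20%, within 5% to 40%.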

Compound 3, a percentage reported as activity, at one dose (the size of the read-out at that dose, not a potency): 45.4%
Beside the measured number, compound 3's estimate is 25.4 percentage points below it; measured number outside the range, above it.
By their numbers in this assay, from the lowest: compounds 2 and 1 (each within the scatter of the next); then compound 3.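

On the saturated chain carbon bound to an amide-type nitrogen and a carbonyl carbon, the choice of group matters in this assay: replacing 1-hydroxyethyl with the group of 7 heavy atoms (4 carbon, 3 nitrogen; no ring) gives a number 26.8 percentage points higher from compound 2 to compound 3 (beyond the scatter). For the compounds shown here, this is the first step here to exceed the scatter, so this position is not indifferent to what it carries. Nothing available explains the rise. From the compounds shown here alone, whether the gain comes from the carbon chain or from the nitrogen atoms remains open; a plain carbon chain or a simple amine on this carbon would help separate the two.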